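Swapping a hydroxy for a methoxy on compound 3

This account rests on a few compounds, and the source may have more. Where it says the series, first, only, none or still open, it means among the compounds named here.

Measured in an ADME assay on THP-1 cells (Homo sapiens) for cytotoxicity, read by flow cytometry and propidium iodide staining, with a stated time of 72 h; on this read-out higher numbers stand for weaker inhibition and lower numbers for stronger inhibition:
compound 1 `CC(=O)Nc1ccc2oc(-c3ccccc3F)c(O)c(=O)c2c1`: 47000 nM
compound 2 `Nc1ccc2oc(-c3ccccc3)c(O)c(=O)c2c1`: 27000 nM
compound 3 `Nc1ccc2oc(-c3ccccc3F)c(O)c(=O)c2c1`: 38000 nM

All three numbers sit close together, and compound 3 at 38000 nM lies within the scatter of both neighbours. Compound 4 `COc1c(-c2ccccc2F)oc2ccc(N)cc2c1=O` has methyl in place of hydrogen on an oxygen on an aromatic ring, that is, hydroxy to methoxy (methyl in place of hydrogen on an oxygen on an aromatic ring). Going by the values given here, no measured step changes this oxygen, so the guide is only indirect. The two known changes, a 1.2-fold lower number from compound 1 to compound 3 (0.09 log units; within the scatter) and a 1.4-fold higher number from compound 2 to compound 3 (0.15 log units; within the scatter), moved the number very little in this assay. With that limited evidence, the expected step is a 1.1-fold lower number from compound 3 to compound 4 (0.04 log units; within the scatter), with no shift in either direction beyond the scatter. For compound 4 the estimated value is 35000 nM, with an expected range of 15000 nM to 80000 nM.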

Compound 4, half-maximal inhibitory concentration: > 125000 nM
Compound 4: a limit, no number; the forecaster's own chance of this, stated with the estimate: 15%; middle value at least 3.5-fold (0.55 log units) from the limit.
By their numbers in this assay, from the lowest: compounds 2, 3 and 1 (each within the scatter of the next). At a limit, above all of these: compound 4.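

In this assay, going by these compounds alone, the earlier steps, at the nitrogen and at the fluoro, stayed within the scatter, whereas hydroxy to methoxy on this oxygen gives an at least 3.2-fold higher number from compound 3 to compound 4 (0.51 log units; beyond the scatter). This oxygen is therefore the first place in the series where a single change moves the number beyond the scatter. Compound 4 gives > 125000 nM, which is a limit of the assay and not a number.

The compounds shown leave open whether a longer chain on this oxygen, such as ethoxy, or an acetyl there would read the same way. They also leave open whether methoxy has this effect on compound 2, which carries hydrogen in place of fluoro.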